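This account rests on a few compounds, and the source may have more. Where it says the series, first, only, none or still open, it means among the compounds named here.

Measured so far in an assay on isolated protein for inhibition of Rho-associated protein kinase 2 (Homo sapiens), read by a luciferase reporter; a lower number here means a stronger inhibitor, a higher number a weaker inhibitor:
compound 1 `CC(C)c1cccc(C2CNCC2C(=O)Nc2cc3cc[nH]c(=O)c3cc2Cl)c1` gives 6 nM
compound 2 `CN1CCC(C(=O)Nc2cc3cc[nH]c(=O)c3cc2Cl)CC1` gives 31 nM

Compound 1 holds the lowest of the two numbers in this assay; compound 2 sits at a higher number, and that gap lies beyond the scatter. Compound 3 `O=C(Nc1cc2cc[nH]c(=O)c2cc1Cl)C1CNCC1c1cccc(Br)c1` is not yet measured. Against compound 1 the change is bromo in place of isopropyl on an aromatic carbon. For the measured compounds named here, no pair of measured compounds traces this exchange, so its size is open; a small step, within the scatter or just past it, is expected, more likely toward a higher number. For compound 3 the expected step is a 1.7-fold higher number from compound 1 to compound 3 (0.22 log units; within the scatter). The estimate for compound 3 in this assay is 10 nM, with a range from 3 nM to 35 nM.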

Compound 3, half-maximal inhibitory concentration: 2 nM
Compound 3: the middle estimate sits 5.0-fold (0.70 log units) above what was measured; the whole stated range lies above it.
By their numbers in this assay, from the lowest: compound 3; then compound 1; then compound 2.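

In this assay, bromo in place of isopropyl gives a 3.0-fold lower number from compound 1 to compound 3 (0.48 log units; beyond the scatter) on this aromatic carbon, the first exchange read at this position. The three carbons of the isopropyl are therefore not needed for a low number here, and a single bromine atom serves better in this pair. No measurement at hand bears on why the number falls.

Going by these compounds, one exchange sets no trend at this position, so how chloro, methoxy, trifluoromethyl or an amine would fare there stays open. On these data alone, whether bromo keeps this step at other places on the aromatic ring also stays open.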